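This account rests on a few compounds, and the source may have more. Where it says the series, first, only, none or still open, it means among the compounds named here.

Compound 1 `Cc1c(C(C)n2cnc3ncc(-c4cn[nH]c4)nc32)ccc2ncccc12` and compound 2 `Cc1c(C(C)n2cnc3ncc(-c4cnn(CCO)c4)nc32)ccc2ncccc12` share one core, and compound 3 `CC(NC/N=C/c1cn[nH]c1)c1ccc2ncccc2c1` and compound 4 `CC(NC/N=C/c1cnn(CCO)c1)c1ccc2ncccc2c1` share another; the difference between the two cores is not broken down here. In a functional assay on NCI-H1993 cells (Homo sapiens) for inhibition, read by CCK-8 assay, with a stated time of 72 h (on this read-out higher numbers stand for weaker inhibition and lower numbers for stronger inhibition), compound 1 gives 599 nM and compound 2 gives 726 nM. The step between them, a 1.2-fold higher number from compound 1 to compound 2 (0.08 log units; within the scatter), is the change 2-hydroxyethyl in place of hydrogen on an aromatic nitrogen and leaves the two values within the scatter of each other, so nothing can be said about which of the two inhibits the cells more strongly. In this assay compound 3 gives 519 nM, a value that sits within the scatter of both compound 1 and compound 2.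

Compound 4 has not yet been measured in this assay. Within the data shown here, it arises from compound 3 by 2-hydroxyethyl in place of hydrogen on an aromatic nitrogen, the same kind of change as the one from compound 1 to compound 2, made at the same place on the five-membered ring. Among the measured compounds shown here, the only guide here is that earlier step, which lay within the scatter on a different core. On that basis the step from compound 3 to compound 4 is expected to be small as well, about a 1.2-fold higher number from compound 3 to compound 4 (0.08 log units; within the scatter), which is a modest expectation because the earlier change gave a 1.2-fold higher number from compound 1 to compound 2 (0.08 log units; within the scatter). For compound 4 in this assay the estimated value is 620 nM, with a likely range from 350 nM to 1100 nM, and that estimate rests on compound 3 giving 519 nM.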

Compound 4, half-maximal inhibitory concentration: 148 nM
Compound 4: middle estimate off by 4.2-fold (0.62 log units), on the high side; the whole stated range lies above it.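

In this assay, putting 2-hydroxyethyl in place of hydrogen on an aromatic nitrogen of the core of compound 3 gives a 3.5-fold lower number from compound 3 to compound 4 (0.54 log units; beyond the scatter), so on this core the change goes with clearly stronger inhibition of the cells. The size of the step does not carry over from one core to the other, and a step seen on one core is therefore a poor guide to the other in this series: the same change on two cores in this assay, a 1.2-fold higher number (0.08 log units; within the scatter) from compound 1 to compound 2 and a 3.5-fold lower number (0.54 log units; beyond the scatter) from compound 3 to compound 4, 4.3-fold (0.63 log units) apart, beyond the scatter of two such steps. Among these compounds, this shows that the outcome of the change depends on the core it is made on, but it rests on only two pairs of compounds and does not show which part of the cores is responsible, why the two steps differ, or how a third core would respond.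

The compounds shown leave open whether the stronger inhibition on the core of compound 3 is specific to 2-hydroxyethyl or would also appear with a plain methyl, a longer chain ending in a hydroxyl, or a chain ending in an amine or a carboxylic acid on the same nitrogen. They also leave open whether any of these groups would move the number beyond the scatter on the core of compound 1.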